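Piperidine amide antagonists: methyl moved on the aryl ring

A few compounds are considered here, and "the series" means these few. Any claim that something is new, unique, unknown or untested is made for them only; others in the source may bear on it.

Three piperidine-carboxamides were measured in a functional assay for antagonist activity at transient receptor potential cation channel subfamily V member 1 (Homo sapiens), read by FLIPR and calcium flux; on this read-out lower numbers stand for stronger inhibition and higher numbers for weaker inhibition. Compound 1 `O=C(Nc1cnc2ccccc2c1)C1CCN(c2cccc(C(F)(F)F)c2)CC1` gives 600 nM. Compound 2 `Cc1cccc(N2CCC(C(=O)Nc3ccc4c(c3)NC(=O)CO4)CC2)c1` gives 490 nM. Compound 3 `CCOC(=O)C1(C)Oc2ccc(NC(=O)C3CCN(c4cc(F)c(F)c(F)c4)CC3)cc2NC1=O` gives 870 nM. Compound 2 carries the lowest of the three numbers, yet its distance to compound 1 and to compound 3 lies within the scatter, so the three compounds cannot be ranked on these data.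

Compound 4 `Cc1ccccc1N1CCC(C(=O)Nc2ccc3c(c2)NC(=O)CO3)CC1` has not yet been measured in this assay. It differs from compound 2 in one place: 2-methylphenyl in place of 3-methylphenyl on an amine nitrogen in a ring. The shared core of compound 2 and compound 4, the amide link and the fused bicyclic amine part are unchanged.

Among the compounds with values here, no pair of measured compounds differs in only one place, so no measured step tells how such a change plays out here. A step of modest size in this assay is expected from compound 2 to compound 4, a 1.6-fold higher number from compound 2 to compound 4 (0.21 log units; within the scatter), with the direction uncertain and possibly within the scatter. Compound 4 is estimated at 800 nM, with a range from 300 nM to 2500 nM.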

Compound 4, half-maximal inhibitory concentration: 150 nM
Compound 4: the middle estimate sits 5.3-fold (0.73 log units) above what was measured; the measured number lies below the stated range.
By their numbers in this assay, from the lowest: compound 4; then compounds 2, 1 and 3 (each within the scatter of the next).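

In this assay, within the data shown here, putting 2-methylphenyl in place of 3-methylphenyl on the amine nitrogen in a ring gives a 3.3-fold lower number from compound 2 to compound 4 (0.51 log units; beyond the scatter), the first step in this set to stand clear of the scatter, as the three earlier compounds could not be ranked. The group that leaves and the group that enters hold the same atoms and the same counts of hydrogen-bond donors and acceptors, so this position responds to where the methyl sits on the aromatic ring, with nothing added or removed. No measurement given here accounts for the size or direction of this step.

The compounds shown leave open how an unsubstituted phenyl, a 2-ethylphenyl or a 2-chlorophenyl would read at this place. They also leave open whether 2-methylphenyl would bring a similar step with the amide part of compound 1 or compound 3.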